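This account rests on a few compounds, and the source may have more. Where it says the series, first, only, none or still open, it means among the compounds named here.

Measured compounds:
Compound 1, `O=S(=O)(Nc1ccc(-c2nc3ccccc3o2)cc1)c1cccs1`: 63000 nM
Compound 2, `O=S(=O)(Nc1ccc(-c2nc3ccccc3o2)cc1)c1ccc(F)cc1`: 73000 nM
Compound 3, `O=S(=O)(Nc1ccc(-c2nc3ccccc3o2)cc1)c1ccc(O)cc1`: 78000 nM

In an assay on cells for inhibition of HSP60/HSP10 (Homo sapiens), with a stated time of 60 min (on this read-out higher numbers stand for weaker inhibition and lower numbers for stronger inhibition), compound 3 gives 78000 nM. It sits among the three numbers by a 1.1-fold higher number from compound 2 to compound 3 (0.03 log units; within the scatter) and by a 1.2-fold higher number from compound 1 to compound 3 (0.09 log units; within the scatter), so the three compounds are not told apart. Compound 4 is `O=S(=O)(Nc1ccc(-c2nc3ccccc3o2)cc1)c1ccc(Cl)c(Cl)c1`; its difference from compound 3 is 3,4-dichlorophenyl in place of 4-hydroxyphenyl on a sulfonyl sulfur. Among the measured compounds shown here, the steps that bear on this are the two that also change the group on the sulfonyl sulfur, a 1.2-fold higher number from compound 1 to compound 2 (0.06 log units; within the scatter) and a 1.2-fold higher number from compound 1 to compound 3 (0.09 log units; within the scatter), and neither leaves the scatter. No step beyond the scatter is therefore expected in this assay for compound 4, in either direction. Compound 4 is expected to give 70000 nM in this assay, between 30000 nM and 160000 nM, which means an expected step of a 1.1-fold lower number from compound 3 to compound 4 (0.05 log units; within the scatter).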

Compound 4, half-maximal inhibitory concentration: 25000 nM
Estimate against measurement, compound 4: 2.8-fold (0.45 log units) above; the measured number lies below the stated range.
By their numbers in this assay, from the lowest: compound 4; then compounds 1, 2 and 3 (each within the scatter of the next).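

In this assay the group on the sulfonyl sulfur now moves the number: there is a 3.1-fold lower number from compound 3 to compound 4 (0.49 log units; beyond the scatter) and a 2.9-fold lower number from compound 2 to compound 4 (0.47 log units; beyond the scatter) and also a 2.5-fold lower number from compound 1 to compound 4 (0.40 log units; beyond the scatter) when 3,4-dichlorophenyl enters, whereas the thiophen-2-yl, 4-fluorophenyl and 4-hydroxyphenyl compounds could not be told apart. This position can therefore respond to a change of group, although all three steps are modest. Nothing available explains the gain seen with this change.

The compounds shown leave open whether a single chlorine on the phenyl ring would do as much as two. They also leave open how an amine or a carboxylic acid on that ring would read.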